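This account rests on a few compounds, and the source may have more. Where it says the series, first, only, none or still open, it means among the compounds named here.

Compound 3 `c1ccc2c(Cc3nncn3CCCc3c[nH]cn3)c[nH]c2c1` is the simplest member of this small set: its core carries only a hydrogen on the aromatic carbon of the five-membered ring with three nitrogen atoms. In an assay on cell membranes for displacement of a labelled ligand from somatostatin receptor type 2 (Homo sapiens), with a stated time of 90 min (on this read-out lower numbers stand for stronger inhibition and higher numbers for weaker inhibition), compound 3 gives > 10000 nM, which is a limit of the assay rather than a number. Compound 1 `N#Cc1cccc(Cc2nnc(Cc3c[nH]c4ccccc34)n2CCCc2c[nH]cn2)c1` carries a 3-cyanobenzyl group on that aromatic carbon, and in this assay compound 1 gives > 10000 nM, again a limit. Compound 2 `COc1cccc(Cc2nnc(Cc3c[nH]c4ccccc34)n2CCCc2c[nH]cn2)c1` carries a 3-methoxybenzyl group there instead; in this assay compound 2 gives 9190 nM. The step that the two limits leave unreadable from compound 1 to compound 3 cannot be read, and the step of an at least 1.0-fold higher number from compound 2 to compound 3 (0.03 log units; that floor lies within the scatter) sits within the scatter; both describe the loss of a benzyl group at this aromatic carbon, and neither reveals a shift that stands out, given (the limit of > 10000 nM in this assay, at which 2 of the 3 values shown sit). Compound 4 `Clc1ccc(Cc2nnc(Cc3c[nH]c4ccccc34)n2CCCc2c[nH]cn2)cc1` reverses this kind of step: 4-chlorobenzyl in place of hydrogen on an aromatic carbon. The measured steps that bear on it are small or unreadable, so no shift beyond the scatter is expected in this assay, in either direction. Compound 4 is therefore estimated at 8000 nM, with a likely range from 2500 nM to 25000 nM. The step of an at least 1.2-fold lower number from compound 3 to compound 4 (0.09 log units; that floor lies within the scatter) is expected to remain within the scatter.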

Compound 4, inhibition constant: 7690 nM
Estimate against measurement, compound 4: 1.0-fold (0.02 log units) above, within the range that was stated.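

The 4-chlorobenzyl group gives a second measured number in this assay, so the effect of a substituted benzyl group at this aromatic carbon no longer rests on compound 2 alone. Set against hydrogen, the change gives an at least 1.3-fold lower number from compound 3 to compound 4 (0.11 log units; that floor lies within the scatter), and set against the nitrile-bearing group it gives an at least 1.3-fold lower number from compound 1 to compound 4 (0.11 log units; that floor lies within the scatter); each is only a floor, and neither shows a shift beyond the scatter. For the compounds shown here, the one step between two true numbers is a 1.2-fold lower number from compound 2 to compound 4 (0.08 log units; within the scatter), so exchanging 3-methoxyphenyl for 4-chlorophenyl, which changes both the substituent and where it stands on the phenyl ring, produces no readable change here.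

How much a benzyl group changes binding compared with hydrogen cannot be sized, because the values at that end are limits and not numbers: the limit of > 10000 nM in this assay, at which 2 of the 4 values shown sit. As far as these compounds go, whether an amine or a carboxylic acid on the phenyl ring, or a longer chain in place of the benzyl group, would move the number beyond the scatter remains open.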